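Chloro to Trifluoromethyl: an Expected Step in Cell Activity

The source may report more compounds than this note shows. Statements on the series, on what has been measured and on what is new or still open speak of the compounds shown alone.

Compound 1 `O=C(Nc1ccc(Cl)cc1)c1cc(=O)[nH]c2cc(Br)ccc12` and compound 2 `O=C(Nc1ccc(C(F)(F)F)cc1)c1cc(=O)[nH]c2cc(Br)ccc12` share a core and differ in one place, namely (trifluoromethyl in place of chloro on an aromatic carbon). In a functional assay on KYSE-410 cells (Homo sapiens) for antiproliferative activity, read by MTT assay, with a stated time of 72 h (on this read-out higher numbers stand for weaker inhibition and lower numbers for stronger inhibition), compound 1 returns only a limit of the assay, > 20000 nM. Compound 2 likewise returns only a limit in this assay, > 20000 nM. The step that the two limits leave unreadable from compound 1 to compound 2 therefore has no readable size, because of the limit of > 20000 nM in this assay, at which 2 of the 3 values shown sit.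

Compound 3 `O=C(Nc1cc(F)cc(F)c1)c1cc(=O)[nH]c2cc(Cl)ccc12` is the only one of the three with a number: in this assay compound 3 gives 11000 nM. The difference between the core of compound 1 and the core of compound 3 is not broken down here.

Compound 4 `O=C(Nc1cc(F)cc(F)c1)c1cc(=O)[nH]c2cc(C(F)(F)F)ccc12` has not yet been measured. It differs from compound 3 by trifluoromethyl in place of chloro on an aromatic carbon. This is the same kind of change as that from compound 1 to compound 2, but not the same: in compound 1 the chloro sits on a six-membered aromatic ring of carbon only, para to a large group, whereas in compound 3 it sits on a six-membered aromatic ring of carbon only, part of a fused or bridged system of two rings, meta to a fused ring and para to a fused ring.

Since a step that the two limits leave unreadable from compound 1 to compound 2 is not readable, the expected step is a small one, no change at the digits printed from compound 3 to compound 4 (within the scatter), resting mainly on the value of compound 3. Compound 4 is thus estimated at 11000 nM in this assay, expected to lie between 4000 nM and 30000 nM.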

Compound 4, half-maximal inhibitory concentration: 17900 nM
For compound 4 the middle estimate is 1.6-fold (0.21 log units) below the measured one; the measured number falls inside the stated range.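

In this assay, trifluoromethyl in place of chloro on an aromatic carbon gives a 1.6-fold higher number from compound 3 to compound 4 (0.21 log units; within the scatter), so on the core shared by compound 3 and compound 4 this change leaves no readable difference in antiproliferative activity. This does not show that the change behaves the same way on another core: the corresponding step between compound 1 and compound 2 cannot be read, because neither compound gives a number, only a limit of the assay: the limit of > 20000 nM in this assay, at which 2 of the 4 values shown sit. That leaves a single readable instance of the change, which cannot show whether its outcome depends on the core and offers no reason for the result.

The compounds shown leave open how a nitrile, a methoxy group or an amine would compare with chloro and trifluoromethyl on the same aromatic carbon, a six-membered aromatic ring of carbon only that is part of a fused or bridged system of two rings. Also open, on these data alone, is whether a carboxylic acid or a longer chain elsewhere on these structures would produce values clearly stronger than those of compound 3 and compound 4, which would give the series a wider range in which to read such steps.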